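The compounds below may be only part of what the source reports. "The series", "measured", "known", "first", "only" and "open" are said of these compounds alone.

Working notes on the sulfonamide series built on a shared core. Compound 1 `CC1CCN(C2CCN(S(=O)(=O)c3cccc(Br)c3)CC2)CC1` carries bromo on an aromatic carbon and in a functional assay on DLD-1 cells (Homo sapiens) for antiproliferative activity, read by CellTiter-Glo, with a stated time of 72 h (a lower number here means a stronger inhibitor, a higher number a weaker inhibitor), compound 1 gives 3.2 nM. Compound 2 `COc1ccccc1-c1cccc(S(=O)(=O)N2CCC(N3CCC(C)CC3)CC2)c1` carries 2-methoxyphenyl in its place, and compound 2 gives 21 nM. Compound 3 `CC1CCN(C2CCN(S(=O)(=O)c3cccc(-c4ccc(Cl)cc4)c3)CC2)CC1` carries 4-chlorophenyl, and compound 3 gives 15 nM. Both biaryl compounds return higher numbers than compound 1: a 6.6-fold higher number from compound 1 to compound 2 (0.82 log units; beyond the scatter) and a 4.7-fold higher number from compound 1 to compound 3 (0.67 log units; beyond the scatter). Between the two biaryls the gap is small, a 1.4-fold lower number from compound 2 to compound 3 (0.15 log units; within the scatter). Compound 3 therefore stands second highest of the three numbers, close to compound 2 and well apart from compound 1.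

Compound 4 `COc1ccc(-c2cccc(S(=O)(=O)N3CCC(N4CCC(C)CC4)CC3)c2)cc1` is not yet measured. Relative to compound 3 the change is methoxy in place of chloro on an aromatic carbon. Going by the values given here, no measured step exchanges these two groups directly. The nearest guide is the comparison of the two biaryls, where 4-chlorophenyl in place of 2-methoxyphenyl gave a 1.4-fold lower number from compound 2 to compound 3 (0.15 log units; within the scatter), within the scatter, so the larger measured effect in this set is the move from bromo to a biaryl rather than the group carried on the added phenyl. The expected step from compound 3 to compound 4 is accordingly a 1.2-fold higher number from compound 3 to compound 4 (0.08 log units; within the scatter), none beyond the scatter. Compound 4 is estimated at 18 nM, with a range of 7 nM to 45 nM.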

Compound 4, half-maximal inhibitory concentration: 23 nM
Compound 4: the middle estimate sits 1.3-fold (0.11 log units) below what was measured, and the stated range covers the measured number.
By their numbers in this assay, from the lowest: compound 1; then compounds 3, 2 and 4 (each within the scatter of the next).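

In this assay the direct exchange of chloro for methoxy, on an aromatic carbon para to a large group, gives a 1.5-fold higher number from compound 3 to compound 4 (0.19 log units; within the scatter) and so does not separate the two groups on the added phenyl. The earlier compounds shown here offered no matched pair for the place of the methoxy on that phenyl, and 4-methoxyphenyl in place of 2-methoxyphenyl now gives a 1.1-fold higher number from compound 2 to compound 4 (0.04 log units; within the scatter), so this change also makes no readable difference here. Going by these compounds alone, the replacement of bromo by a substituted phenyl remains the one kind of change beyond the scatter, now seen with a third biaryl in a 7.2-fold higher number from compound 1 to compound 4 (0.86 log units; beyond the scatter), and none of the three biaryls goes against it.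

Nothing available speaks to the reason for any of these steps. Still open, going by these compounds, is whether a group of another kind on the added phenyl, such as an amine or a carboxylic acid, would leave the number where compound 2, compound 3 and compound 4 sit, and whether a nitrile in place of the bromo of compound 1 would hold the value of compound 1.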